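Hydroxy in place of acetamido on the aromatic ring

The compounds below may be only part of what the source reports. "The series", "measured", "known", "first", "only" and "open" are said of these compounds alone.

Three compounds have been measured in a functional assay on M14 cells (Homo sapiens) for antiproliferative activity, with a stated time of 72 h; on this read-out lower numbers stand for stronger inhibition and higher numbers for weaker inhibition:
compound 1 `C=CC[C@H]1C[C@]2([C@@H](C)Cc3ccc(OC)c(OC)c3)OCOC2=CC1=O`, 110 nM;
compound 2 `C=CC[C@H]1C[C@]2([C@@H](C)Cc3ccc(OC)c(C)c3)OCOC2=CC1=O`, 410 nM;
compound 3 `C=CC[C@H]1C[C@]2([C@@H](C)Cc3ccc(OC)c(NC(C)=O)c3)OCOC2=CC1=O`, 85 nM.

Compound 3 gives the lowest of the three numbers, but the nearest step to it, a 1.3-fold lower number from compound 1 to compound 3 (0.11 log units; within the scatter), lies within the scatter, so no order can be set between these two. Going by the values given here, the furthest step, a 4.8-fold lower number from compound 2 to compound 3 (0.68 log units; beyond the scatter), lies beyond the scatter, as does a 3.7-fold higher number from compound 1 to compound 2 (0.57 log units; beyond the scatter); methyl at this position is thus the one change that moves the number by a modest amount.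

Compound 4 `C=CC[C@H]1C[C@]2([C@@H](C)Cc3ccc(OC)c(O)c3)OCOC2=CC1=O` is not yet measured. The change from compound 3 is hydroxy in place of acetamido on an aromatic carbon. The two steps that bear on it both end at compound 3: methoxy and acetamido gave numbers within the scatter of each other, while methyl gave a modestly higher one. Hydroxy, like acetamido, brings one hydrogen-bond donor and one acceptor, so compound 4 is expected to land close to compound 3, with a 1.5-fold higher number from compound 3 to compound 4 (0.18 log units; within the scatter) at most a small step that may sit within the scatter. The estimate for compound 4 in this assay is 130 nM, with a range from 50 nM to 400 nM.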

Compound 4, half-maximal inhibitory concentration: 8 nM
The estimate for compound 4 lay 16-fold (1.21 log units) above the measured number; measured number below the stated range.
By their numbers in this assay, from the lowest: compound 4; then compounds 3 and 1 (each within the scatter of the next); then compound 2.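

In this assay the earlier changes at this place on the aromatic ring, ortho to a methoxy group, had moved the number by a modest amount at most, whereas hydroxy in place of acetamido gives an 11-fold lower number from compound 3 to compound 4 (1.03 log units; beyond the scatter) and so opens a large step where none had been seen. Removing only the methyl from the oxygen of compound 1 gives a 14-fold lower number from compound 1 to compound 4 (1.14 log units; beyond the scatter) and the widest gap in the set is a 51-fold lower number from compound 2 to compound 4 (1.71 log units; beyond the scatter) so compound 4 stands beyond the scatter from all three others and is the most potent of the four on this read-out. Acetamido and hydroxy carry the same counts of hydrogen-bond donors and acceptors, so those counts do not separate compound 3 from compound 4, and nothing measured here accounts for the difference between them.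

The compounds shown leave open whether an amine or a hydroxymethyl group at this place would give a number near that of compound 4 or one near those of compound 1 and compound 3. They also leave open whether hydroxy would have the same effect in place of the other methoxy group, or in cells other than those of this assay.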